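A Cyano Group Repeated on a Second Core

This account rests on a few compounds, and the source may have more. Where it says the series, first, only, none or still open, it means among the compounds named here.

Of the compounds shown here, three have been measured in a functional assay on C6 cells (Rattus norvegicus) for cytotoxicity, read by MTT assay, with a stated time of 24 h, tested at 200 ug/mL; on this read-out lower numbers stand for a stronger effect and higher numbers for a weaker effect at the one concentration tested. Compound 2 `Cn1cnnc1SCC(=O)N/N=c1/scc(-c2ccccc2)n1-c1ccccc1` gives 35.5%. Compound 1 `Cn1cnnc1SCC(=O)N/N=c1/scc(-c2ccc(C#N)cc2)n1-c1ccccc1` differs from it by cyano in place of hydrogen on an aromatic carbon, and in this assay compound 1 gives 52.6%, which is a number 17.1 percentage points higher from compound 2 to compound 1 (beyond the scatter). Compound 3 `O=C(CSc1nnnn1-c1ccccc1)N/N=c1/scc(-c2ccccc2)n1-c1ccccc1` gives 22.6% in this assay, so that a number 12.9 percentage points lower from compound 2 to compound 3 (beyond the scatter). Compound 3 thus gives the lowest number of the three, its steps to both others lying beyond the scatter.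

Compound 4 `N#Cc1ccc(-c2cs/c(=N/NC(=O)CSc3nnnn3-c3ccccc3)n2-c2ccccc2)cc1` has not yet been measured. It differs from compound 3 by cyano in place of hydrogen on an aromatic carbon. The surroundings of this change read word for word as they do for the change from compound 2 to compound 1, so it is the same change, only made on the core of compound 3; the two cores differ by 1-phenyl-1H-tetrazol-5-yl in place of 4-methyl-4H-1,2,4-triazol-3-yl on a sulfur. In this assay a step of about a number 16.9 percentage points higher from compound 3 to compound 4 (beyond the scatter) is expected for compound 4, resting on the earlier step of a number 17.1 percentage points higher from compound 2 to compound 1 (beyond the scatter) that the same change produced once before. With a single precedent the range stays wide. Compound 4 is estimated at 39.5%, between 27% and 53%.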

Compound 4, a percentage reported as activity, at one concentration (the size of the read-out at that concentration, not a potency): 54%
Estimate against measurement, compound 4: 14.5 percentage points below; measured number outside the range, above it.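

In this assay the cyano group moves the number in the same direction on both cores, but the new step, a number 31.4 percentage points higher from compound 3 to compound 4 (beyond the scatter), is not a copy of the earlier one, so the direction carried over while the size did not: the same change on two cores in this assay, a number 17.1 percentage points higher (beyond the scatter) from compound 2 to compound 1 and a number 31.4 percentage points higher (beyond the scatter) from compound 3 to compound 4, 14.3 percentage points apart, beyond the scatter of two such steps

Seen from the other side, the swap of the ring on the sulfur, which lowered the number on the core without cyano, gives only a number 1.4 percentage points higher from compound 1 to compound 4 (within the scatter) once cyano is present, so the two changes do not simply add up: the same change on two cores in this assay, a number 12.9 percentage points lower (beyond the scatter) from compound 2 to compound 3 and a number 1.4 percentage points higher (within the scatter) from compound 1 to compound 4, 14.3 percentage points apart, beyond the scatter of two such steps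

Across these four compounds, then, the size of the cyano step depends on the group on the sulfur, but the data do not show why, and two cores cannot predict the step on a third.

On these data alone, whether a methoxy group, a fluorine atom or a carboxylic acid on the same aromatic carbon would follow cyano remains open, as does the behaviour of a simple methyl group on the sulfur. As far as these compounds go, each result also comes from a single concentration, so how these compounds compare at other concentrations stays unknown.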